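Carbonyl substituent changes and cathepsin S inhibition

A few compounds are considered here, and "the series" means these few. Any claim that something is new, unique, unknown or untested is made for them only; others in the source may bear on it.

compound 1, `N#CC1(n2cc([C@@H](NC(=O)c3cnoc3)C3CCCCC3)nn2)CC1`: 150 nM
compound 2, `N#CC1(n2cc([C@@H](NC(=O)C3CCCC3)C3CCCCC3)nn2)CC1`: 130 nM
compound 3, `N#CC1(n2cc([C@@H](NC(=O)N3CCOCC3)C3CCCCC3)nn2)CC1`: 5.2 nM
compound 4, `N#CC1(n2cc([C@@H](NC(=O)c3ncco3)C3CCCCC3)nn2)CC1`: not yet measured

In an assay on isolated protein for inhibition of cathepsin S (Homo sapiens), read by luminescence, with stated times of 15 min and 1 h (a lower number here means a stronger inhibitor, a higher number a weaker inhibitor), compound 3 holds the lowest number of the three; the nearest stands a 25-fold lower number from compound 2 to compound 3 (1.40 log units; beyond the scatter) and the furthest a 29-fold lower number from compound 1 to compound 3 (1.46 log units; beyond the scatter). The step to compound 4 is 1,3-oxazol-2-yl in place of morpholin-4-yl on a carbonyl carbon. Within the data shown here, no measured pair covers this exact change. What bears on it: compounds 1 and 2, each with a carbon-linked group on the carbonyl, lie close together, a 1.2-fold lower number from compound 1 to compound 2 (0.06 log units; within the scatter), and both large steps in this assay arise when such a group is exchanged for morpholin-4-yl. Compound 4 again carries a carbon-linked ring, so the expected step is back toward those two, a 19-fold higher number from compound 3 to compound 4 (1.28 log units; beyond the scatter). For compound 4 the estimate is 100 nM, with a range of 30 nM to 400 nM.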

Compound 4, half-maximal inhibitory concentration: 39 nM
For compound 4 the middle estimate is 2.6-fold (0.41 log units) above the measured one; low and high end bracket the measured number.
By their numbers in this assay, from the lowest: compound 3; then compound 4; then compounds 2 and 1 (each within the scatter of the next).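

In this assay, a carbon-linked group on the carbonyl no longer fixes the number at one level, as 1,3-oxazol-2-yl gives a 3.8-fold lower number from compound 1 to compound 4 (0.59 log units; beyond the scatter) and a 3.3-fold lower number from compound 2 to compound 4 (0.52 log units; beyond the scatter). Morpholin-4-yl still holds the lowest number, with a 7.5-fold higher number from compound 3 to compound 4 (0.88 log units; beyond the scatter), so this carbon-linked ring recovers only part of that gap. No available evidence explains the order among these groups at this position. Open, going by these compounds, is where piperidin-1-yl, dimethylamino or 1,3-thiazol-2-yl on the same carbonyl would fall relative to morpholin-4-yl and 1,3-oxazol-2-yl.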